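A 4-Methylphenyl to 4-Chlorophenyl Change on a Shared Core

The compounds below may be only part of what the source reports. "The series", "measured", "known", "first", "only" and "open" are said of these compounds alone.

In a functional assay on RCC4 cells (Homo sapiens) for antiproliferative activity, read by XTT assay, with a stated time of 48 h (on this read-out higher numbers stand for weaker inhibition and lower numbers for stronger inhibition), compound 1 (`CCS(=O)(=O)N(Cc1cn([C@@H]2O[C@H](COC(C)=O)[C@@H](OC(C)=O)[C@H]2OC(C)=O)nn1)c1ccc(Cl)cc1`) stands at 250000 nM and compound 2 (`CC(=O)OC[C@H]1O[C@@H](n2cc(CN(c3ccc(C)cc3)S(=O)(=O)c3ccccc3)nn2)[C@H](OC(C)=O)[C@@H]1OC(C)=O`) at 230000 nM so these two numbers lie within the scatter of each other. Compared with compound 2, compound 3 (`CC(=O)OC[C@H]1O[C@@H](n2cc(CN(c3ccc(Cl)cc3)S(=O)(=O)c3ccccc3)nn2)[C@H](OC(C)=O)[C@@H]1OC(C)=O`) carries chloro in place of methyl on an aromatic carbon, para to a large group (chloro in place of methyl on an aromatic carbon). Among the compounds with values here, no measured pair shows this change, so no step beyond the scatter is expected in this assay in either direction. The expected step is small (a 1.2-fold lower number from compound 2 to compound 3 (0.06 log units; within the scatter)). For compound 3 the estimated value is 200000 nM (expected range 90000 nM to 400000 nM).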

Compound 3, half-maximal inhibitory concentration: 250000 nM
The estimate for compound 3 lay 1.3-fold (0.10 log units) below the measured number; the range from low to high includes it.
By their numbers in this assay, from the lowest: compounds 2, 1 and 3 (each within the scatter of the next).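

In this assay, within the data shown here, chloro in place of methyl on an aromatic carbon gives a 1.1-fold higher number from compound 2 to compound 3 (0.04 log units; within the scatter) in the first measured pair with this change, and phenyl in place of ethyl on a sulfonyl sulfur gives no change at the digits printed from compound 1 to compound 3 (within the scatter) as well. Neither change at these two places moves the number beyond the scatter. Nothing available bears on why this is so. Going by these compounds, whether an amine or a carboxylic acid in place of chloro on that aromatic carbon would move the number beyond the scatter stays open, as does the effect of a longer chain on the sulfonyl sulfur.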